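Glucoside hydrazones: positional chloro swap, single-concentration inhibition

A few compounds are considered here, and "the series" means these few. Any claim that something is new, unique, unknown or untested is made for them only; others in the source may bear on it.

Three compounds share one core and differ only in the group on the carbon with a double bond to nitrogen. In a functional assay on MDA-MB-231 cells (Homo sapiens) for inhibition, read by MTT assay, with a stated time of 24 h, tested at 100 uM (on this read-out higher numbers stand for more inhibition at the one concentration tested (going by the name of the read-out) and lower numbers for less inhibition), compound 1 `O=C(N/N=C/c1ccc(F)cc1)c1ccc(O[C@@H]2O[C@H](CO)[C@@H](O)[C@H](O)[C@H]2O)cc1` gives 9.91%. Compound 2 `O=C(N/N=C/C1CCCCC1)c1ccc(O[C@@H]2O[C@H](CO)[C@@H](O)[C@H](O)[C@H]2O)cc1` gives 0.88% in this assay, and compound 3 `O=C(N/N=C/c1ccc(Cl)cc1)c1ccc(O[C@@H]2O[C@H](CO)[C@@H](O)[C@H](O)[C@H]2O)cc1` gives 2.26%. Compound 3 stands second highest of the three numbers, with compound 2 nearest and compound 1 furthest, though every gap among them lies within the scatter: a number 9 percentage points lower from compound 1 to compound 2 (within the scatter), a number 7.7 percentage points lower from compound 1 to compound 3 (within the scatter) and a number 1.4 percentage points higher from compound 2 to compound 3 (within the scatter).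

Compound 4 `O=C(N/N=C/c1cccc(Cl)c1)c1ccc(O[C@@H]2O[C@H](CO)[C@@H](O)[C@H](O)[C@H]2O)cc1` is not yet measured. Its change from compound 3 is 3-chlorophenyl in place of 4-chlorophenyl on a carbon with a double bond to nitrogen. For the measured compounds named here, no measured step moves a chloro from one aromatic carbon to another; the nearest comparison is the chloro-for-fluoro swap a number 7.7 percentage points lower from compound 1 to compound 3 (within the scatter), and the aryl-for-cyclohexyl swaps above, all within the scatter. Nothing in these numbers points to a step beyond the scatter, so compound 4 is expected to sit near compound 3, the expected step being a number 1.2 percentage points higher from compound 3 to compound 4 (within the scatter). The estimate for compound 4 in this assay is 3.5%, within 0% to 12%.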

Compound 4, a percentage reported as inhibition, at one concentration (the size of the read-out at that concentration, not a potency): 5.02%
Compound 4: middle estimate off by 1.5 percentage points, on the low side; the range from low to high includes it.
By their numbers in this assay, from the lowest: compounds 2, 3, 4 and 1 (each within the scatter of the next).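

In this assay, for the compounds shown here, the swap of 3-chlorophenyl for 4-chlorophenyl, the only step here that keeps the same atoms and joins them differently, reads a number 2.8 percentage points higher from compound 3 to compound 4 (within the scatter) and so shows no separation between the two chlorophenyl groups at this place. The 3-chlorophenyl group also stays unresolved from the other two groups, with a number 4.1 percentage points higher from compound 2 to compound 4 (within the scatter) and a number 4.9 percentage points lower from compound 1 to compound 4 (within the scatter), so all four groups on the carbon with a double bond to nitrogen remain within the scatter of one another at the one concentration tested. No evidence on hand bears on this result.

Still open, on these data alone, is whether any group at this place can give a step beyond the scatter, such as a 4-aminophenyl, a 4-carboxyphenyl or a longer alkyl chain. A single-concentration percentage also leaves the potency of all four compounds open.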